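The source may report more compounds than this note shows. Statements on the series, on what has been measured and on what is new or still open speak of the compounds shown alone.

Three amides sharing one core have been measured so far in a functional assay on PC-3 cells (Homo sapiens) for antiproliferative activity, read by MTT assay, with a stated time of 48 h (on this read-out higher numbers stand for weaker inhibition and lower numbers for stronger inhibition), on this series. For the measured compounds named here, compound 1 `CCn1c(C(=O)NCCCN(C)C)ccc1C(CC)(CC)c1ccc(OCCC(O)(CC)CC)c(C)c1` gives 2150 nM there, the only exact number among them. Compound 2 `CCn1c(C(=O)N(CCC#N)CCC#N)ccc1C(CC)(CC)c1ccc(OCCC(O)(CC)CC)c(C)c1` reads > 50000 nM and this is a limit, not a number. Compound 3 `CCn1c(C(=O)Nc2ccc(OC(F)(F)F)cc2)ccc1C(CC)(CC)c1ccc(OCCC(O)(CC)CC)c(C)c1` reads > 50000 nM and this is also a limit, not a number. Compound 3 therefore has no exact value and sits with one other compound at the limit of > 50000 nM in this assay, at which 2 of the 3 values shown sit, in this series.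

The next compound, compound 4 `CCOC(=O)CN(C)C(=O)c1ccc(C(CC)(CC)c2ccc(OCCC(O)(CC)CC)c(C)c2)n1CC`, differs from compound 3 in one place: ((ethoxycarbonyl)methyl)(methyl)amino in place of (4-(trifluoromethoxy)phenyl)amino on a carbonyl carbon is the change. Neither group carries a net charge. Going by the values given here, two measured steps bear on it. Both an at least 23-fold higher number from compound 1 to compound 2 (1.36 log units; beyond the scatter) and an at least 23-fold higher number from compound 1 to compound 3 (1.36 log units; beyond the scatter) are large, and each replaces the group of compound 1 on the amide. The step that the two limits leave unreadable from compound 2 to compound 3 cannot be sized, so it adds little. Compound 4 also lacks the 3-(dimethylamino)propyl group of compound 1, so after an at least 23-fold higher number from compound 1 to compound 2 (1.36 log units; beyond the scatter) weak inhibition is expected again.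

The estimated change is an at least 1.6-fold lower number from compound 3 to compound 4 (0.22 log units; that floor lies within the scatter) and it points, if anywhere, toward a lower number, with another result at the limit quite possible. For compound 4 the expected value is 30000 nM with an estimated range from 8000 nM to 50000 nM in this test.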

Compound 4, half-maximal inhibitory concentration: 7140 nM
For compound 4 the middle estimate is 4.2-fold (0.62 log units) above the measured one; the measured number lies below the stated range.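

In this assay, putting ((ethoxycarbonyl)methyl)(methyl)amino on the carbonyl carbon gives an at least 7.0-fold lower number from compound 3 to compound 4 (0.84 log units; beyond the scatter), and the comparison with the bis-nitrile amide gives an at least 7.0-fold lower number from compound 2 to compound 4 (0.84 log units; beyond the scatter). Compound 4 does not fully match the one basic-chain amide in the set, as the remaining gap is a 3.3-fold higher number from compound 1 to compound 4 (0.52 log units; beyond the scatter), yet it shows that a group with no net charge can give a readable value at this position. A measurable value here therefore does not require the (3-(dimethylamino)propyl)amino group, although compound 2 and compound 3 go against any idea that other replacements will generally give one, and both remain limits: the limit of > 50000 nM in this assay, at which 2 of the 4 values shown sit.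

The step between compound 2 and compound 3 cannot be read, and nothing shown separates the contributions of the ethyl ester, the methyl on the amide nitrogen and the loss of the amide hydrogen. A carboxylic acid in place of the ethyl ester, or a plain dimethylamino group on the carbonyl carbon, would help show which of these parts matters.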